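A Benzothiophene Takes the Place of a Methylphenyl Group

The source may hold more compounds than are shown below. What is called first, only, known or untested is meant among the compounds shown, and "the series" means these compounds.

Of the compounds shown here, three sharing one core have been tested in a functional assay on BV-2 cells (Mus musculus) for inhibition, read by ELISA, with a stated time of 16 h; a lower number here means a stronger inhibitor, a higher number a weaker inhibitor. Compound 1 `Cc1cc(Cl)nnc1N1CCN(c2ncccn2)CC1` reaches only the limit of > 100000 nM. Compound 2 `Cc1cc(C(C)C)nnc1N1CCN(c2ncccn2)CC1` likewise gives only the limit of > 100000 nM. Compound 3 `Cc1ccc(-c2cc(C)c(N3CCN(c4ncccn4)CC3)nn2)cc1` alone gives a number, 17200 nM. The two remaining values are limits. The steps of an at least 5.8-fold lower number from compound 1 to compound 3 (0.76 log units; beyond the scatter) and an at least 5.8-fold lower number from compound 2 to compound 3 (0.76 log units; beyond the scatter) supply the only readable gains, and both arrive at the same 4-methylphenyl group. Compound 4 `Cc1cc(-c2cc3ccccc3s2)nnc1N1CCN(c2ncccn2)CC1` differs from compound 3 by 1-benzothiophen-2-yl in place of 4-methylphenyl on an aromatic carbon. An aromatic ring thus remains at that carbon, so the step is expected to stay within the scatter, estimated as a 1.4-fold lower number from compound 3 to compound 4 (0.16 log units; within the scatter). Compound 4 is therefore expected to give about 12000 nM, between 3500 nM and 45000 nM.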

Compound 4, half-maximal inhibitory concentration: 24900 nM
Compound 4: the middle estimate sits 2.1-fold (0.32 log units) below what was measured, and the stated range covers the measured number.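

In this assay the step of a 1.4-fold higher number from compound 3 to compound 4 (0.16 log units; within the scatter) shows that 1-benzothiophen-2-yl serves at this carbon as well as 4-methylphenyl, so the measurable activity is not tied to that one group. The steps of an at least 4.0-fold lower number from compound 2 to compound 4 (0.60 log units; beyond the scatter) and an at least 4.0-fold lower number from compound 1 to compound 4 (0.60 log units; beyond the scatter) show a second aromatic group at this position doing better than isopropyl and chloro. Both steps start from compounds that give only a limit, not a number: the limit of > 100000 nM in this assay, at which 2 of the 4 values shown sit.

On these data alone, whether a cyclohexyl ring, or an aromatic group carrying an amine or a carboxylic acid, would keep this level stays open.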